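The compounds below may be only part of what the source reports. "The series", "measured", "known", "first", "only" and "open" are said of these compounds alone.

Measured so far in a toxicity assay on THP-1 cells (Homo sapiens) for inhibition; on this read-out lower numbers stand for higher toxicity in this test and higher numbers for lower toxicity in this test:
compound 1 `Cn1c(-c2ccccc2Cl)cnc1NC(=O)c1ccc(F)cc1`: > 50000 nM
compound 2 `Cn1c(-c2cccc(Br)c2)cnc1NC(=O)c1ccc(F)cc1`: > 50000 nM

Both entries are limits of the assay and not numbers. Compound 2 stands at > 50000 nM, a limit. The evidence is thin: the limit of > 50000 nM in this assay, at which 2 of the 2 values shown sit.

The next step leads to compound 3 `Cn1c(-c2ccccc2Br)cnc1NC(=O)c1ccc(F)cc1`, where 2-bromophenyl replaces 3-bromophenyl on an aromatic carbon of a five-membered aromatic ring with 2 nitrogen: 2-bromophenyl in place of 3-bromophenyl on an aromatic carbon.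

Among the compounds with values here, the only measured step that bears on this is a step that the two limits leave unreadable from compound 1 to compound 2. Compound 1 already carries 2-chlorophenyl and shows > 50000 nM, a limit. No step beyond the scatter is therefore expected in this assay, and no direction can be assigned. The estimated step is a number no higher from compound 2 to compound 3 (the limit leaves the size open). For compound 3 the expected value is 50000 nM, with an estimated range from 30000 nM to 80000 nM.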

Compound 3, half-maximal cytotoxic concentration: > 100000 nM
Compound 3: no number, only a limit; the forecaster's own chance of this, stated with the estimate: 90%; at least 2.0-fold (0.30 log units) between middle value and limit.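

In this assay compound 3 gives > 100000 nM, a limit and not a number. Within the data shown here, no step among compound 1, compound 2 and compound 3 can be read: all three entries are limits. The compounds shown leave open at what concentration any of them would reach half-maximal toxicity in this assay.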